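This account rests on a few compounds, and the source may have more. Where it says the series, first, only, none or still open, it means among the compounds named here.

Of the compounds shown here, three have so far been measured in a physicochemical assay for acid dissociation. Compound 3 `COc1cccc(CNCCCNc2ccnc3cc(-c4ccccc4)ccc23)c1O` gives 9.47. Compound 2 `c1ccc(-c2ccc3c(NCCCNCc4ccco4)ccnc3c2)cc1` gives 9.47; its core differs from that of compound 3 by furan-2-yl in place of 2-hydroxy-3-methoxyphenyl on a saturated chain carbon bound to an amine nitrogen, and the two values show no change at the digits printed from compound 2 to compound 3 (within the scatter). Compound 1 `COc1ccc(Oc2ccc3c(NCCCNCc4cccc(OC)c4O)ccnc3c2)cc1` gives 9.28. It arises from compound 3 by 4-methoxyphenoxy in place of phenyl on an aromatic carbon, a change that brought a number 0.19 log units lower from compound 3 to compound 1 (within the scatter).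

Compound 4 `COc1ccc(Oc2ccc3c(NCCCNCc4ccco4)ccnc3c2)cc1` has not yet been measured. Within the data shown here, it arises from compound 2 by 4-methoxyphenoxy in place of phenyl on an aromatic carbon, which is the same change as the one that turns compound 3 into compound 1, made on the core of compound 2 rather than on that of compound 3. The two cores differ only in the way already described between compound 3 and compound 2, and that difference left the acid dissociation constant unaltered at the digits reported. Among the measured compounds shown here, the sole precedent for the change, then, is the single step from compound 3 to compound 1, and a single step within the scatter gives no strong reason to expect any marked movement.

The step from compound 2 to compound 4 in this assay is expected to be a number 0.17 log units lower from compound 2 to compound 4 (within the scatter), because the same change gave a number 0.19 log units lower from compound 3 to compound 1 (within the scatter). Compound 4 is accordingly estimated at 9.3, with an expected range from 9 to 9.6.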

Compound 4, acid dissociation constant: 9.28
Compound 4: middle estimate off by 0.02 log units, on the high side; measured number inside the range.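

In this assay, 4-methoxyphenoxy in place of phenyl on the core bearing furan-2-yl gave one step (a number 0.19 log units lower from compound 2 to compound 4 (within the scatter)), and it reads the same at the digits printed as the step for this change on the core bearing 2-hydroxy-3-methoxyphenyl (a number 0.19 log units lower from compound 3 to compound 1 (within the scatter)), while the exchange of those two groups with 4-methoxyphenoxy in place gave a further step (no change at the digits printed from compound 1 to compound 4 (within the scatter)). The change therefore carried from one core to the other without any sign, in these four compounds, that what happens at the aromatic carbon depends on the group at the far end of the chain. This does not show that the change has a real effect on the number, since every step here lies within the scatter, nor do two cores make a rule for others, and nothing at hand speaks to the reason for these values.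

The compounds shown leave open whether the same agreement would hold with a carboxylic acid or an amine in place of phenyl on that aromatic carbon. They also leave open whether it would survive a longer chain, or a pyridine ring in place of furan-2-yl, on the other side of the molecule.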